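This account rests on a few compounds, and the source may have more. Where it says the series, first, only, none or still open, it means among the compounds named here.

Measured so far in a functional assay on SK-OV-3 cells (Homo sapiens) for antiproliferative activity, read by MTT assay, with a stated time of 72 h; on this read-out higher numbers stand for weaker inhibition and lower numbers for stronger inhibition:
- compound 1 `O=C(CCc1cccc2c1B(O)OC2)Nc1cccc(Br)c1`: 540 nM
- compound 2 `O=C(CCc1cccc2c1B(O)OC2)Nc1cccc(-c2ccc(F)cc2)c1`: 93 nM
- compound 3 `O=C(CCc1cccc2c1B(O)OC2)Nc1cccc(-c2cccc(Cl)c2)c1`: 300 nM

Compound 3 does not separate from the bromo starting point, with a 1.8-fold lower number from compound 1 to compound 3 (0.26 log units; within the scatter). It does separate from the remaining measured compound, with a 3.2-fold higher number from compound 2 to compound 3 (0.51 log units; beyond the scatter).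

Next is compound 4 `COc1cc(OC)cc(-c2cccc(NC(=O)CCc3cccc4c3B(O)OC4)c2)c1`, with 3,5-dimethoxyphenyl in place of 3-chlorophenyl on an aromatic carbon.

Within the data shown here, the closest precedent is the exchange of one substituted phenyl for another at this same place, a 3.2-fold higher number from compound 2 to compound 3 (0.51 log units; beyond the scatter), a modest step. Replacing bromo gave a 5.8-fold lower number from compound 1 to compound 2 (0.76 log units; beyond the scatter) in one case and a 1.8-fold lower number from compound 1 to compound 3 (0.26 log units; within the scatter) in the other, so the size of the effect depends on the phenyl group. Among the measured compounds shown here, no measured compound carries a methoxy group, which leaves the direction open. A modest step either way is possible, but no step beyond the scatter is expected.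

The estimate implies a 1.5-fold lower number from compound 3 to compound 4 (0.18 log units; within the scatter), an expected change that stays small. For compound 4 the expected value in this assay is 200 nM, with an estimated range of 70 nM to 600 nM.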

Compound 4, half-maximal inhibitory concentration: 44 nM
For compound 4 the middle estimate is 4.5-fold (0.66 log units) above the measured one; the whole stated range lies above it.
By their numbers in this assay, from the lowest: compound 4; then compound 2; then compounds 3 and 1 (each within the scatter of the next).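

In this assay, among these compounds, this place on an aromatic carbon, meta to a large group, proves more responsive to the choice of substituted phenyl than the earlier compounds showed: 3,5-dimethoxyphenyl in place of 3-chlorophenyl gives a clear gain (a 6.8-fold lower number from compound 3 to compound 4 (0.83 log units; beyond the scatter)). Among the compounds shown here, the new group also goes past 4-fluorophenyl (a 2.1-fold lower number from compound 2 to compound 4 (0.33 log units; beyond the scatter)), so compound 4 now has the lowest number of the four, and the change from bromo becomes the first large step at this place (a 12-fold lower number from compound 1 to compound 4 (1.09 log units; beyond the scatter)). Nothing available explains this gain.

From the compounds shown here alone, whether a phenyl with a single methoxy group would match 3,5-dimethoxyphenyl remains open. So does the outcome with an amine or a carboxylic acid on that phenyl, or with morpholine in its place.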